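Removing Bromine from the Furan of a Hydroxamic Acid

The source may hold more compounds than are shown below. What is called first, only, known or untested is meant among the compounds shown, and "the series" means these compounds.

Measured compounds:
compound 1 `Cc1ccc(-c2nc(CNc3ccc(C(=O)NO)cc3)n(-c3ccccc3)n2)cc1` — 62.2%
compound 2 `O=C(NO)c1ccc(NCc2nc(-c3ccc(Br)o3)nn2-c2ccccc2)cc1` — 55.8%

In an assay on Sf9 cells for inhibition of protein deacetylase HDAC6 (Homo sapiens), read by fluorescence, with a stated time of 40 min, tested at 100 nM (on this read-out higher numbers stand for more inhibition at the one concentration tested (going by the name of the read-out) and lower numbers for less inhibition), compound 1 gives 62.2% and compound 2 gives 55.8%. Going by the values given here, compound 2 carries the lower of the two numbers, but the only measured step, a number 6.4 percentage points lower from compound 1 to compound 2 (within the scatter), lies within the scatter, so the two compounds cannot be ordered. Compound 3 `O=C(NO)c1ccc(NCc2nc(-c3ccco3)nn2-c2ccccc2)cc1` is not yet measured; it differs from compound 2 by hydrogen in place of bromo on an aromatic carbon. Among the compounds with values here, no measured step touches this change: the one step in hand, from compound 1 to compound 2, swaps a whole aryl group and remained within the scatter, which gives no guidance on the bromine itself. On this basis no step beyond the scatter is expected, and the estimated change a number 3.8 percentage points lower from compound 2 to compound 3 (within the scatter) is small. Compound 3 is therefore expected to give about 52% in this assay, between 36% and 66%.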

Compound 3, a percentage reported as inhibition, at one concentration (the size of the read-out at that concentration, not a potency): 59.9%
Compound 3: the middle estimate sits 7.9 percentage points below what was measured; the range from low to high includes it.
By their numbers in this assay, from the lowest: compounds 2, 3 and 1 (each within the scatter of the next).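

Going from bromo to hydrogen on the furan ring, next to the ring oxygen, gives a number 4.1 percentage points higher from compound 2 to compound 3 (within the scatter) in this assay and so does not separate 5-bromofuran-2-yl from furan-2-yl at this single concentration. The bare furan-2-yl group also gives a number 2.3 percentage points lower from compound 1 to compound 3 (within the scatter) when set against 4-methylphenyl, so the bromine is not needed for compound 3 to stay level with compound 1 on this read-out. No other measurement at hand bears on this result.

The compounds shown leave open whether an amine or a carboxylic acid on this same furan carbon would also stay within the scatter or would move the number clearly. They also leave open whether compound 2 and compound 3 would differ in a full concentration series.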